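Replacing a bulky sulfone by a hydroxyalkyl chain

A few compounds are considered here, and "the series" means these few. Any claim that something is new, unique, unknown or untested is made for them only; others in the source may bear on it.

Measured compounds in a functional assay on the whole organism (strain ICR) for inhibition, with Mus musculus as the target, with a stated time of 4 h, at a dose of 10 mg/kg by the oral route; on this read-out lower numbers stand for less inhibition and higher numbers for more inhibition at the one dose given (going by the name of the read-out):
Compound 1, `Cn1c(-c2ccccc2C(F)(F)F)nnc1C12CCC(CCS(C)(=O)=O)(CC1)CC2`, gives 96% in this assay.
Compound 2, `Cn1c(-c2ccccc2C(F)(F)F)nnc1C12CCC(CCS(=O)(=O)C(C)(C)C)(CC1)CC2`, gives 65% in this assay.
Compound 3, `CC(C)S(=O)(=O)CCC12CCC(c3nnc(-c4ccccc4C(F)(F)F)n3C)(CC1)CC2`, gives 88% in this assay.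

Compound 2 stands lowest of the three numbers in this assay. Its nearest neighbour is compound 3, reached by a number 23 percentage points higher from compound 2 to compound 3 (beyond the scatter), and the furthest is compound 1, which lies a number 31 percentage points lower from compound 1 to compound 2 (beyond the scatter) in the other direction. The third measured step, a number 8 percentage points lower from compound 1 to compound 3 (within the scatter), does not separate compound 1 from compound 3.

Compound 4, `CC(O)CCCC12CCC(c3nnc(-c4ccccc4C(F)(F)F)n3C)(CC1)CC2`, arises from compound 2 through the change (2-hydroxypropyl in place of (tert-butyl)sulfonyl on a saturated chain carbon, two bonds along the chain from a saturated ring carbon). Going by the values given here, no measured step removes the sulfonyl group itself, so the steps bear on this change only indirectly: both a number 31 percentage points lower from compound 1 to compound 2 (beyond the scatter) and a number 23 percentage points higher from compound 2 to compound 3 (beyond the scatter) show that the largest group on the sulfonyl sulfur went with the lowest inhibition, and the change to compound 4 removes that group along with the sulfonyl. Among the compounds with values here, the step expected for compound 4 is therefore upward in this assay, estimated as a number 15 percentage points higher from compound 2 to compound 4 (beyond the scatter), though the hydroxyl that enters has no measured counterpart and widens the uncertainty. Compound 4 is thus expected to give about 80% in this assay, in a range from 50% to 97%.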

Compound 4, a percentage reported as inhibition, in the whole organism at one dose (the size of the read-out at that dose, not a potency): 97%
The estimate for compound 4 lay 17 percentage points below the measured number; the measured number falls inside the stated range.
By their numbers in this assay, from the lowest: compound 2; then compounds 3, 1 and 4 (each within the scatter of the next).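

In this assay, the sulfonyl group proves dispensable at this position among the compounds shown: moving from the (tert-butyl)sulfonyl group to the 2-hydroxypropyl group gives a number 32 percentage points higher from compound 2 to compound 4 (beyond the scatter) and recovers everything lost in compound 2. The same change made on the other two sulfones separates nothing, with a number 9 percentage points higher from compound 3 to compound 4 (within the scatter) and a number 1 percentage points higher from compound 1 to compound 4 (within the scatter) as the two readings, so a chain with a hydroxyl and no sulfur stands level with the isopropylsulfonyl and methylsulfonyl groups, and compound 2 alone falls away from the rest. Nothing measured here speaks to what lies behind these steps.

Going by these compounds, what remains open is whether the hydroxyl contributes at all, since a plain pentyl chain, a ketone on the same carbon or a carboxylic acid at the chain end would test that directly. Compounds 1, 3 and 4 also cannot be told apart at the single dose and time of this assay, so any ranking among them would need a full dose series or a lower dose.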